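Compound 4 Takes Over Where Compound 3 Meets the Limit

The compounds below may be only part of what the source reports. "The series", "measured", "known", "first", "only" and "open" are said of these compounds alone.

Compound 3 `CC(C)C/N=C(\S)NCCCCn1nc(-c2ccccc2)ccc1=O` is the starting point of this step. In a functional assay on the whole organism (stomach) with Rattus norvegicus as the target (on this read-out lower numbers stand for an effect already at smaller amounts and higher numbers for an effect only at larger amounts of compound), compound 3 gives only a limit, > 100 mg/kg. Its closest measured relative, compound 1 `CCC/N=C(/NC#N)NCCCCn1nc(-c2ccccc2)ccc1=O`, likewise gives only a limit in this assay, > 100 mg/kg. Compound 2 `CCC/N=C(/NC#N)NCCCn1nc(-c2ccccc2)ccc1=O` has a chain one carbon shorter than compound 1. In this assay compound 2 gives 100 mg/kg. Within the data shown here, the one measured step that reaches compound 3, a step that the two limits leave unreadable from compound 1 to compound 3, cannot be sized, and the limit of > 100 mg/kg in this assay, at which 2 of the 3 values shown sit, leaves compound 3 standing at the edge of what this assay can report rather than on a number. Compound 4 `C/N=C(/NC#N)N(C)CCCCn1nc(-c2ccccc2)ccc1=O` differs from compound 3 by a group of 8 heavy atoms (4 carbon, 4 nitrogen; no ring) in place of a group of 8 heavy atoms (5 carbon, 2 nitrogen, 1 sulfur; no ring), on a saturated chain carbon, four bonds along the chain from an aromatic nitrogen. No measured step sizes this exchange; the nearest one, a step that the two limits leave unreadable from compound 1 to compound 3, runs in the opposite direction and is itself unreadable. The chemist therefore expects compound 4 to stay near the limit, with the step that the limit leaves unreadable from compound 3 to compound 4 not expected to exceed the scatter. Compound 4 is estimated at 150 mg/kg, between 60 mg/kg and 500 mg/kg.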

Compound 4, dose for half-maximal effect: > 100 mg/kg
Compound 4: only a limit was reported; the forecaster's own chance of this, stated with the estimate: 70%; the middle value does not contradict the limit.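

No step can be read from compound 3 to compound 4, because both compounds end at the same limit rather than on a number: the limit of > 100 mg/kg in this assay, at which 3 of the 4 values shown sit.

The compounds shown leave open whether the group entering in compound 4 differs at all from the group leaving compound 3 in this assay.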